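Swapping Dichlorophenoxy for Fluorophenoxy on a Shared Core

The compounds below may be only part of what the source reports. "The series", "measured", "known", "first", "only" and "open" are said of these compounds alone.

For the measured compounds named here, compound 1 `Nc1cc(N)c2nc(-c3ccccc3)c(Oc3ccc(Cl)c(Cl)c3)nc2c1` is the only compound here with an actual number: in a functional assay on HCT-116 cells (Homo sapiens) for inhibition, read by sulforhodamine B assay, with a stated time of 48 h (a higher number here means a weaker inhibitor of growth, a lower number a stronger inhibitor of growth), compound 1 gives 47900 nM. Compound 2 `CCOC(=O)[C@H](CCC(=O)O)NC(=O)c1ccc(CNc2nc3cc(N)cc(N)c3nc2-c2ccccc2)cc1` reaches only a limit of this assay, < 100000 nM, not a number. Compound 3 `CCOC(=O)[C@H](CCC(=O)O)NC(=O)c1ccc(Sc2nc3cc(N)cc(N)c3nc2-c2ccccc2)cc1` likewise stops at a limit of this assay, < 100000 nM. The evidence on hand is thin: the limit of < 100000 nM in this assay, at which 2 of the 3 values shown sit. Compound 4 `Nc1cc(N)c2nc(-c3ccccc3)c(Oc3ccc(F)cc3)nc2c1` differs from compound 1 by 4-fluorophenyl in place of 3,4-dichlorophenyl on an oxygen on an aromatic ring. Going by the values given here, no step between measured compounds is available to guide this change, so the expected step of a 1.3-fold higher number from compound 1 to compound 4 (0.10 log units; within the scatter) is taken as a modest weakening, not clearly beyond the scatter. Compound 4 is therefore estimated at 60000 nM, with a range from 20000 nM to 180000 nM.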

Compound 4, concentration for total growth inhibition: 81300 nM
Compound 4: middle estimate off by 1.4-fold (0.13 log units), on the low side; the measured number falls inside the stated range.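

In this assay the exchange of 3,4-dichlorophenyl for 4-fluorophenyl on an oxygen on an aromatic ring gives a 1.7-fold higher number from compound 1 to compound 4 (0.23 log units; within the scatter) and so does not separate the two groups. At this place on the shared core, then, the pair of chlorines and the single fluorine cannot be told apart by this read-out. Nothing in the data shown accounts for this step.

Still open, on these data alone, is whether a carboxylic acid or an amine on this phenyl ring would move the number beyond the scatter. Also open, as far as these compounds go, is what a longer alkyl chain on the oxygen, in place of the aromatic ring, would do.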